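Pyridine for thiophene on the shared core: cytotoxicity outlook

This account rests on a few compounds, and the source may have more. Where it says the series, first, only, none or still open, it means among the compounds named here.

Compound 1 `Oc1cccc(-c2cc(-c3ccc(Cl)cc3)nc(-c3cccs3)c2)c1` carries a thiophen-2-yl group, a 4-chlorophenyl group and a 3-hydroxyphenyl group on the shared core. In an ADME assay on HEK293 cells (Homo sapiens) for cytotoxicity, read by CCK-8 assay and cell counting, with a stated time of 2 days (on this read-out lower numbers stand for stronger inhibition and higher numbers for weaker inhibition), compound 1 gives 11800 nM, the highest of the two numbers available in the series. Compound 3 `Oc1ccc(-c2cc(-c3ccsc3)nc(-c3cccc(Cl)c3)c2)cc1` gives 2670 nM in this assay, a lower number that lies beyond the scatter. Compound 2 `Oc1cccc(-c2cc(-c3ccncc3)nc(-c3ccccc3Cl)c2)c1` gives "not determined" (no result reported) in this assay, so no number is available for it. Compound 4 `Oc1cccc(-c2cc(-c3ccc(Cl)cc3)nc(-c3cccnc3)c2)c1` keeps the 4-chlorophenyl and 3-hydroxyphenyl groups of compound 1; the change is pyridin-3-yl in place of thiophen-2-yl on an aromatic carbon. Among the compounds with values here, no measured pair isolates this change, and compound 1 and compound 3 differ in several places at once, so their gap gives no direct guide to it. The step expected here is a 1.3-fold higher number from compound 1 to compound 4 (0.10 log units; within the scatter), judged a small move, if any, toward a higher number in this assay. Compound 4 is therefore estimated at 15000 nM in this assay, within a range of 5000 nM to 45000 nM.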

Compound 4, half-maximal inhibitory concentration: 39500 nM
Compound 4: middle estimate off by 2.6-fold (0.42 log units), on the low side; low and high end bracket the measured number.
By their numbers in this assay, from the lowest: compound 3; then compound 1; then compound 4.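

Pyridin-3-yl in place of thiophen-2-yl is the first change in the series that can be read in one place: in this assay it gives a 3.3-fold higher number from compound 1 to compound 4 (0.52 log units; beyond the scatter) with the 4-chlorophenyl and 3-hydroxyphenyl groups held constant. This aromatic carbon, next to the ring nitrogen, is therefore not indifferent to which ring it carries, and this exchange moves the number toward weaker inhibition. Nothing measured here explains the step.

With this single pair, the ring size and the hetero atom change together and cannot be told apart. Open questions are where a plain phenyl group or an amine at this carbon would fall, and whether the step holds alongside other groups on the shared core.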